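A few compounds are considered here, and "the series" means these few. Any claim that something is new, unique, unknown or untested is made for them only; others in the source may bear on it.

Measured in a functional assay for inhibition, with Rattus norvegicus as the target, at pH 7.35; on this read-out higher numbers stand for weaker inhibition and lower numbers for stronger inhibition:

- compound 1 `CCOC(=O)C(=O)C(CC)NC(=O)C(CC(C)C)NC(=O)OCc1ccccc1`: 300000 nM
- compound 2 `CCOC(=O)C(=O)C(CC)NC(=O)C(CC(C)C)NC(=O)C(CC)Oc1ccccc1`: 22000 nM
- compound 3 `CCOC(=O)C(=O)C(CC)NC(=O)C(CC(C)C)NC(=O)OCC(C)C`: > 300000 nM (a limit of the assay, not a number)

Of the two actual numbers, compound 1 holds the higher, so it is the weaker of that pair. The next compound, compound 4 `CCC(NC(=O)C(CC(C)C)NC(=O)OCc1ccccc1)C(=O)C(=O)NCC1CCCCC1`, is not yet measured. It differs from compound 1 by one change: (cyclohexylmethyl)amino in place of ethoxy on a carbonyl carbon.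

Within the data shown here, no measured step touches this place, since all three measured compounds keep the ethoxy group. The steps made elsewhere therefore give only indirect guidance. One is a 14-fold lower number from compound 1 to compound 2 (1.13 log units; beyond the scatter), with 1-phenoxypropyl in place of benzyloxy on a carbonyl carbon. Another is an at least 13-fold higher number from compound 2 to compound 3 (1.13 log units; beyond the scatter), with isobutoxy in place of 1-phenoxypropyl on a carbonyl carbon. The third, a number no lower from compound 1 to compound 3 (the limit leaves the size open), has no readable size. Together they show that a single change can move this read-out a long way in this assay. Upward, little can be read, given (the limit of > 300000 nM in this assay, at which 1 of the 3 values shown sits).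

Among the measured compounds shown here, a lower number is expected, though with low confidence, and a smaller move than the one to compound 2. The expected change is a 5.0-fold lower number from compound 1 to compound 4 (0.70 log units; beyond the scatter). For compound 4 the estimated value is 60000 nM, with an expected range of 8000 nM to 300000 nM.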

Compound 4, half-maximal inhibitory concentration: 66000 nM
Compound 4: the middle estimate sits 1.1-fold (0.04 log units) below what was measured, and the stated range covers the measured number.
By their numbers in this assay, from the lowest: compound 2; then compound 4; then compound 1.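

Among these compounds, compound 4 gives the only reading so far at this position, the carbonyl carbon whose other neighbour is a carbonyl carbon, and it shows that the ethoxy group is not essential for activity. In this assay, among the compounds shown here, replacing ethoxycarbonyl with (cyclohexylmethyl)carbamoyl gives a 4.5-fold lower number from compound 1 to compound 4 (0.66 log units; beyond the scatter), so a change on this side of the molecule, not only at the benzyloxy end altered in the earlier compounds, can shift the read-out. The swap changes several things at once: it brings in more heavy atoms, a six-membered carbon ring and a hydrogen-bond donor, and it removes an oxygen that counts as a hydrogen-bond acceptor, so this one step cannot show which of these matters.

Separating those features would take groups at this position such as methylamino, benzylamino or dimethylamino, which has no amide hydrogen, and none of these appears among the compounds shown. Replacements that weaken compound 1 further could also be hard to size, and so the downside of this position remains poorly defined: the limit of > 300000 nM in this assay, at which 1 of the 4 values shown sits.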